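The source may report more compounds than this note shows. Statements on the series, on what has been measured and on what is new or still open speak of the compounds shown alone.

Values measured in a functional assay on A549 cells (Homo sapiens) for inhibition, read by MTT assay, with a stated time of 48 h; a lower number here means a stronger inhibitor, a higher number a weaker inhibitor:

- Compound 1 `Cn1c(/C=C2\SC(=O)N(CC(=O)Nc3cc(C(C)(C)C)on3)C2=O)nc2ccccc21`: 15300 nM
- Compound 2 `CCn1c(/C=C2\SC(=O)N(CC(=O)N3CCCCC3)C2=O)nc2ccccc21`: > 50000 nM, a limit of the assay and not a number
- Compound 3 `CCn1c(/C=C2\SC(=O)N(CC(=O)Nc3cc(C(C)(C)C)on3)C2=O)nc2ccccc21`: 44800 nM

For the measured compounds named here, only two of these values are actual numbers, and the one for compound 3 is the higher, which marks the weaker inhibitor of that pair. The gap is a 2.9-fold higher number from compound 1 to compound 3 (0.47 log units; beyond the scatter). That step is methyl in place of hydrogen on a saturated chain carbon bound to an aromatic nitrogen, so it concerns a different place from the change followed here.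

Compound 4 `CCn1c(/C=C2\SC(=O)N(CC(=O)N3CC(C)OC(C)C3)C2=O)nc2ccccc21` keeps the shared core but carries 2,6-dimethylmorpholin-4-yl in place of (5-(tert-butyl)-1,2-oxazol-3-yl)amino on a carbonyl carbon. The measured step that bears on this change acts on the same carbonyl carbon, with (5-(tert-butyl)-1,2-oxazol-3-yl)amino in place of piperidin-1-yl. It is an at least 1.1-fold lower number from compound 2 to compound 3 (0.04 log units; that floor lies within the scatter), so it offers only a floor and gives no real size to build on. On that evidence, no step beyond the scatter is expected in this assay, in either direction. A report of only a limit would be no surprise, given (the limit of > 50000 nM in this assay, at which 1 of the 3 values shown sits). The expected step is a 1.1-fold higher number from compound 3 to compound 4 (0.05 log units; within the scatter). For compound 4 the estimated value is 50000 nM, with an expected range of 22000 nM to 110000 nM.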

Compound 4, half-maximal inhibitory concentration: > 50000 nM
Compound 4 ended at the assay's limit; the forecaster's own chance of this, stated with the estimate: 55%; the middle value lies on the limit itself.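

Placing 2,6-dimethylmorpholin-4-yl on the carbonyl carbon instead of (5-(tert-butyl)-1,2-oxazol-3-yl)amino gives, in this assay, an at least 1.1-fold higher number from compound 3 to compound 4 (0.04 log units; that floor lies within the scatter), so the two groups cannot be told apart at this position and compound 3 shows no advantage beyond the scatter. Compound 2 showed this for piperidin-1-yl, and compound 4 now shows that a second non-aromatic ring, one with a ring oxygen and two methyl groups, also ends at a limit of the assay and not at a number: the limit of > 50000 nM in this assay, at which 2 of the 4 values shown sit. The step between compound 2 and compound 4 cannot be read, as both values are limits.

As far as these compounds go, it remains open whether a different group on this carbonyl carbon, such as a simple dimethylamino or a phenylamino group, would give a number clearly under that limit. The only step shown beyond the scatter is a 2.9-fold higher number from compound 1 to compound 3 (0.47 log units; beyond the scatter), and whether the same change on the chain would matter with piperidin-1-yl or 2,6-dimethylmorpholin-4-yl in place is also unknown.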